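The source may report more compounds than this note shows. Statements on the series, on what has been measured and on what is new or still open speak of the compounds shown alone.

Notes on the amide-terminated series.

Compound 1 `CCCCCCCCCCCC[C@@H](O)[C@H]1CC[C@H]([C@H](O)CCCCCCCCCCNC(=O)c2cccs2)O1` gives 1510 nM in a functional assay on MKN-74 cells (Homo sapiens) for inhibition, read by colorimetric assay and sulforhodamine B assay, with a stated time of 48 h; on this read-out higher numbers stand for weaker inhibition of growth and lower numbers for stronger inhibition of growth. Compound 2 `CCCCCCCCCCCC[C@@H](O)[C@H]1CC[C@H]([C@H](O)CCCCCCCCCCNC(=O)c2ccco2)O1` gives 1700 nM, and compound 3 `CCCCCCCCCCCC[C@@H](O)[C@H]1CC[C@H]([C@H](O)CCCCCCCCCCNC(=O)c2ccsc2)O1` gives 1510 nM. The three swaps among them all sit on the carbonyl carbon of the amide: a 1.1-fold higher number from compound 1 to compound 2 (0.05 log units; within the scatter), no change at the digits printed from compound 1 to compound 3 (within the scatter) and a 1.1-fold lower number from compound 2 to compound 3 (0.05 log units; within the scatter). Compound 1 thus stands level with compound 3 at the digits printed, and every gap among the three lies within the scatter, so no ordering among them can be claimed.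

Compound 4 `CCCCCCCCCCCC[C@@H](O)[C@H]1CC[C@H]([C@H](O)CCCCCCCCCCNC(=O)c2ccnn2C)O1` is the next member. (1-methyl-1H-pyrazol-5-yl in place of thiophen-2-yl on a carbonyl carbon). All three measured steps exchange one five-membered aromatic ring for another at this same carbonyl carbon and none moves the number beyond the scatter; the change to compound 4 is of the same kind, though it brings the only ring with two hetero atoms and two hydrogen-bond acceptors into the set. On that basis no step beyond the scatter is expected in this assay, in either direction, and the estimated step is a 1.0-fold higher number from compound 1 to compound 4 (0.01 log units; within the scatter). Compound 4 is therefore expected to give about 1550 nM, with a range from 750 nM to 3200 nM.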

Compound 4, concentration for 50% growth inhibition: 3890 nM
For compound 4 the middle estimate is 2.5-fold (0.40 log units) below the measured one; the whole stated range lies below it.
By their numbers in this assay, from the lowest: compounds 1, 3 and 2 (each within the scatter of the next); then compound 4.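

In this assay, the ring on this carbonyl carbon is no longer without consequence: a 2.6-fold higher number from compound 1 to compound 4 (0.41 log units; beyond the scatter), a 2.6-fold higher number from compound 3 to compound 4 (0.41 log units; beyond the scatter) and a 2.3-fold higher number from compound 2 to compound 4 (0.36 log units; beyond the scatter), all beyond the scatter, whereas the thiophen-2-yl, thiophen-3-yl and furan-2-yl amides could not be told apart. The ring that separates itself is 1-methyl-1H-pyrazol-5-yl, and it differs from the other rings in both its ring nitrogens and its methyl group, so these steps cannot assign the shift to either one. Nothing available explains the shift.

On these data alone, it remains open whether the unmethylated 1H-pyrazol-5-yl ring would give a number nearer compound 1 or nearer compound 4. A six-membered ring such as phenyl or pyridin-2-yl on the same carbonyl carbon is also untested among the compounds shown here.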